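Compound 2 gains a 3-methoxyphenyl group

A few compounds are considered here, and "the series" means these few. Any claim that something is new, unique, unknown or untested is made for them only; others in the source may bear on it.

For the measured compounds named here, in a physicochemical assay for lipophilicity, using the shake flask method, in phosphate buffer, measured as octanol-water partition, with a stated time of 24 h, at pH 7.4 (on this read-out higher numbers stand for higher lipophilicity and lower numbers for lower lipophilicity), compound 2 `O=S1(=O)CCc2c(C3CC3)nn(-c3ccccc3F)c2O1` gives 2.09, the lower of the two numbers so far, while compound 1 `O=S1(=O)CC(c2cccc(F)c2)c2c(C3CC3)nn(-c3ccccc3F)c2O1` gives 2.86. Compound 3 `COc1cccc(C2CS(=O)(=O)Oc3c2c(C2CC2)nn3-c2ccccc2F)c1` has 3-methoxyphenyl in place of hydrogen on a saturated ring carbon of compound 2: 3-methoxyphenyl in place of hydrogen on a saturated ring carbon. Going by the values given here, one measured step bears on this change, the swap of 3-fluorophenyl for hydrogen on a saturated ring carbon, a number 0.77 log units lower from compound 1 to compound 2 (beyond the scatter). That step is modest but beyond the scatter. The new change runs the opposite way, adding a similar ring, so a rise of comparable size is expected: a number 0.76 log units higher from compound 2 to compound 3 (beyond the scatter). Compound 3 is estimated at 2.85, with an expected range of 2.5 to 3.2.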

Compound 3, partition coefficient: 2.01
Beside the measured number, compound 3's estimate is 0.84 log units above it; the whole stated range lies above it.
By their numbers in this assay, from the lowest: compounds 3 and 2 (each within the scatter of the next); then compound 1.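

In this assay placing 3-methoxyphenyl on this saturated ring carbon gives a number 0.08 log units lower from compound 2 to compound 3 (within the scatter) and so shows that adding an aromatic ring here need not shift the number. Methoxy in place of fluoro on an aromatic carbon gives a number 0.85 log units lower from compound 1 to compound 3 (beyond the scatter) so the higher number of compound 1 does not come from the added ring alone, and what sits on that ring counts. The data offered here give no measured explanation for this difference.

On these data alone, whether an amine or a carboxylic acid in place of the methoxy would leave the number near that of compound 3 or that of compound 1 remains open.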